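Azetidine Replaces an Anilino Group in a Fused Core

The compounds below may be only part of what the source reports. "The series", "measured", "known", "first", "only" and "open" are said of these compounds alone.

Compound 1 `COc1ccc(NC2=CC(=O)c3nc4n(c3C2=O)[C@H]2OC[C@@H](O)[C@H]2OC4)cc1` gives > 4000 nM in a functional assay on ECa-109 cells for inhibition, with ECa-109 cell line (Homo sapiens) as the target, read by sulforhodamine B assay (on this read-out lower numbers stand for stronger inhibition and higher numbers for weaker inhibition), which is a limit of the assay and not a number.
Compound 2 `CCOc1ccccc1NC1=CC(=O)c2nc3n(c2C1=O)[C@H]1OC[C@@H](O)[C@H]1OC3` gives 4630 nM in this assay.
Compound 3 `CCOc1ccc(NC2=CC(=O)c3nc4n(c3C2=O)[C@H]2OC[C@@H](O)[C@H]2OC4)cc1` gives 3210 nM in this assay.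

Compound 1 stands only at a limit, (the limit of > 4000 nM in this assay, at which 1 of the 3 values shown sits), so its own number is not known. Compound 4 `O=C1C=C(N2CCC2)C(=O)c2c1nc1n2[C@H]2OC[C@@H](O)[C@H]2OC1` differs from compound 1 by azetidin-1-yl in place of (4-methoxyphenyl)amino on a double-bonded ring carbon. The measured steps that touch compound 1 change only the aromatic ring attached to the amine nitrogen: a step that the limit leaves unreadable from compound 1 to compound 2 and an at least 1.2-fold lower number from compound 1 to compound 3 (0.09 log units; that floor lies within the scatter). Between the other two, a 1.4-fold lower number from compound 2 to compound 3 (0.16 log units; within the scatter). Going by the values given here, none of these replaces the whole (4-methoxyphenyl)amino group with a small saturated ring, so no measured step bears directly on the change to compound 4. What the three measured compounds do show is that they all sit close together at weak inhibition. With nothing pointing either way, the expected step is a step that the limit leaves unreadable from compound 1 to compound 4, wide open in both directions. Compound 4 is therefore expected to give about 5000 nM, within a range from 1500 nM to 20000 nM.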

Compound 4, half-maximal inhibitory concentration: > 16000 nM
Compound 4 was reported as a limit; the forecaster's own chance of this, stated with the estimate: 40%; middle value at least 3.2-fold (0.50 log units) away from the limit.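

Compound 4 gives > 16000 nM, a limit of the assay and not a number. Going by these compounds alone, compound 1 also stands only at a limit, so no step between compound 1 and compound 4 can be read. As far as these compounds go, how far azetidin-1-yl in place of (4-methoxyphenyl)amino shifts inhibition, and in which direction, stays open.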